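Notes on the series: from compound 1 to compound 3

The source may hold more compounds than are shown below. What is called first, only, known or untested is meant among the compounds shown, and "the series" means these compounds.

Measured in a functional assay on HCT-116 cells (Homo sapiens) for antiproliferative activity, read by MTT assay, with a stated time of 48 h; a lower number here means a stronger inhibitor of growth, a higher number a weaker inhibitor of growth:
- compound 1 `CCN(Cc1ccc(C(=O)NO)cc1)c1ncc(-c2ccc(C)cc2)s1`: 6870 nM
- compound 2 `Cc1ccc(OCCCN(Cc2ccc(C(=O)NO)cc2)c2ncc(-c3ccc(C)cc3)s2)cc1`: 12600 nM

Not yet measured: compound 3 `Cc1ccc(OCCCCN(Cc2ccc(C(=O)NO)cc2)c2ncc(-c3ccc(C)cc3)s2)cc1`.

For the measured compounds named here, the numbers offer only one comparison for compound 1, namely a 1.8-fold higher number from compound 1 to compound 2 (0.26 log units; within the scatter), so it cannot be separated from its sole measured neighbour. The structural change under review is 2-(4-methylphenoxy)ethyl in place of hydrogen on a saturated chain carbon, two bonds along the chain from a nitrogen on an aromatic ring. The measured step placed (4-methylphenoxy)methyl on a saturated chain carbon, two bonds along the chain from a nitrogen on an aromatic ring, and compound 3 carries 2-(4-methylphenoxy)ethyl at that same place. Going by the values given here, this single step is the only evidence, and no series of chain lengths is available. On the evidence of a 1.8-fold higher number from compound 1 to compound 2 (0.26 log units; within the scatter), no change beyond the scatter is expected in this assay. The expected step is a 1.5-fold higher number from compound 1 to compound 3 (0.16 log units; within the scatter). For compound 3 the estimated value is 10000 nM, with an expected range of 4000 nM to 25000 nM.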

Compound 3, concentration for 50% growth inhibition: 580 nM
Beside the measured number, compound 3's estimate is 17-fold (1.24 log units) above it, and the stated range ends above it.
By their numbers in this assay, from the lowest: compound 3; then compounds 1 and 2 (each within the scatter of the next).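

In this assay, the saturated chain carbon two bonds along the chain from a nitrogen on an aromatic ring proves sensitive to what it carries: 2-(4-methylphenoxy)ethyl gives a 12-fold lower number from compound 1 to compound 3 (1.07 log units; beyond the scatter), whereas (4-methylphenoxy)methyl gave only a 1.8-fold higher number from compound 1 to compound 2 (0.26 log units; within the scatter). With the 4-methylphenoxy end kept, placing (4-methylphenoxy)methyl in place of 4-methylphenoxy on a saturated chain carbon, three bonds along the chain from that nitrogen, gives a 22-fold lower number from compound 2 to compound 3 (1.34 log units; beyond the scatter). In these compounds, the presence of the 4-methylphenoxy group alone therefore does not set the number; the length of the chain carrying it matters as well.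

Nothing shown here bears on the reason for this large difference. Going by these compounds, whether a longer chain keeps this level of growth inhibition, and whether an amine or a carboxylic acid can take the place of the 4-methylphenoxy end, remain open.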